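Fluoro in place of methyl: a stability estimate

The compounds below may be only part of what the source reports. "The series", "measured", "known", "first", "only" and "open" are said of these compounds alone.

Results in an ADME assay on microsomes from liver (Homo sapiens) for metabolic stability, with a stated time of 10 min; a higher number here means that more of the compound is left, a lower number that less of the compound is left
- compound 1 (`COC[C@]1(C(=O)N2CC[C@](c3ccc(C(F)(C(F)(F)F)C(F)(F)F)cc3)(S(=O)(=O)c3ccc(F)cc3)C2)CC[C@H](C(=O)O)CC1`) gives 100%
- compound 2 (`O=C(O)C12CCC(C(=O)N3CC[C@](c4ccc(C(F)(C(F)(F)F)C(F)(F)F)cc4)(S(=O)(=O)c4ccc(F)cc4)C3)(CC1)C2`) gives "not determined" (no result reported)
- compound 3 (`CC1(C(=O)N2CC[C@](c3ccc(C(F)(C(F)(F)F)C(F)(F)F)cc3)(S(=O)(=O)c3ccc(F)cc3)C2)CCS(=O)(=O)CC1`) gives "not determined" (no result reported)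

From the compounds shown here alone, compound 3 has no single number to stand on, so its place on this scale is unknown. Compound 4 (`O=C(N1CC[C@](c2ccc(C(F)(C(F)(F)F)C(F)(F)F)cc2)(S(=O)(=O)c2ccc(F)cc2)C1)C1(F)CCS(=O)(=O)CC1`) has yet to be measured. The change (fluoro in place of methyl on a saturated ring carbon) is fluoro in place of methyl on a saturated ring carbon. Going by the values given here, no measured pair shows what such a swap does, so the expectation is weakly grounded: no shift beyond the scatter in this assay, in either direction. Among the compounds with values here, the only number available comes from compound 1 (100%), which differs from compound 4 in more than this one place, so the range stays wide. Compound 4 is expected to give an estimated 85% (range 60% to 100%).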

Compound 4, percent of the compound remaining: 100%
For compound 4 the middle estimate is 15 percentage points below the measured one; the range from low to high includes it.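

In this assay, replacing 4-carboxy-1-(methoxymethyl)cyclohexyl with 4-fluoro-1,1-dioxothian-4-yl on the carbonyl carbon gives no change at the digits printed from compound 1 to compound 4 (within the scatter), so the reading at this place holds with no carboxylic acid present. The change from methyl to fluoro itself cannot be read, as compound 3 has no single number. Nothing measured here explains the result. Still open, from the compounds shown here alone, is whether a hydroxyl group or an amine on the same saturated ring carbon would give a similar reading.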